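The source may hold more compounds than are shown below. What is called first, only, known or untested is meant among the compounds shown, and "the series" means these compounds.

Measured compounds:
- compound 1, `O=C(Nc1ccc(-n2ccc3c(NC(=O)c4ccccc4)ncnc32)cc1)c1ccc(Cl)c(C(F)(F)F)c1`, 2300 nM
- compound 2, `O=C(Nc1ccc(-n2ccc3c(NC(=O)c4ccccc4)ncnc32)cc1)Nc1ccc(Cl)c(Cl)c1`, 4000 nM

Of the compounds shown here, two have been measured in a functional assay on A375P cells (Homo sapiens) for antiproliferative activity, read by MTT assay, with a stated time of 24 h; on this read-out lower numbers stand for stronger inhibition and higher numbers for weaker inhibition. Compound 1 and compound 2 share a core and differ only at one amide-bearing end; the step of a 1.7-fold higher number from compound 1 to compound 2 (0.24 log units; within the scatter), so the two numbers sit within the scatter of each other and neither can be called the stronger.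

Compound 3, `CC(=O)Nc1ncnc2c1ccn2-c1ccc(NC(=O)c2ccc(Cl)c(C(F)(F)F)c2)cc1`, has not been measured. It differs from compound 1 at the other end of the molecule: methyl in place of phenyl on a carbonyl carbon. Among the compounds with values here, the one measured step changes a different place and so does not speak to this change. With no step bearing on it, the size and direction of the change cannot be read from the numbers shown, and the expectation must stay wide. The step of a 2.2-fold higher number from compound 1 to compound 3 (0.34 log units; beyond the scatter) is expected. Compound 3 is estimated at 5000 nM, with a range from 1500 nM to 20000 nM.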

Compound 3, half-maximal inhibitory concentration: > 10000 nM
Compound 3: a limit, no number; the forecaster's own chance of this, stated with the estimate: 10%; middle value at least 2.0-fold (0.30 log units) from the limit.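

Swapping the group on this carbonyl carbon matters in this assay: benzoyl to acetyl gives an at least 4.3-fold higher number from compound 1 to compound 3 (0.63 log units; beyond the scatter). This is the first change among the compounds shown that moves the number beyond the scatter, as the one earlier step, at the other end of the molecule, stayed within it. Compound 3 gives > 10000 nM, which is a limit of the assay and not a number: the limit of > 10000 nM in this assay, at which 1 of the 3 values shown sits.

Only phenyl and methyl appear on this carbonyl carbon, and nothing shows how a longer chain such as propyl, a cyclohexyl ring or a phenyl bearing an amine would read. Within the data shown here, the methyl change is also seen only with 4-chloro-3-(trifluoromethyl)phenyl at the other end, and whether it would run the same way with the (3,4-dichlorophenyl)amino group of compound 2 remains open.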